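A few compounds are considered here, and "the series" means these few. Any claim that something is new, unique, unknown or untested is made for them only; others in the source may bear on it.

Measured so far:
compound 1 `O=C(Nc1cc(C(F)(F)F)cc(C(F)(F)F)c1)c1cc(Cl)c(-c2ccccc2)cc1O` — 560 nM
compound 2 `O=C(Nc1cc(C(F)(F)F)cc(C(F)(F)F)c1)c1ccc(-c2ccccc2)cc1O` — 1580 nM

Among the compounds with values here, in a functional assay on NALM-6 cells (Homo sapiens) for cytotoxicity, read by luminescence and CellTiter-Glo, with a stated time of 3 days (a higher number here means a weaker inhibitor, a lower number a stronger inhibitor), compound 1 gives 560 nM and stands lowest of the two numbers; compound 2 gives 1580 nM, and the only measured step, a 2.8-fold higher number from compound 1 to compound 2 (0.45 log units; beyond the scatter), is modest. Compound 3 `O=C(Nc1cc(C(F)(F)F)cc(C(F)(F)F)c1)c1cc(Cl)c(F)cc1O` differs from compound 1 by fluoro in place of phenyl on an aromatic carbon. Within the data shown here, no measured step bears on this change; the step from compound 1 to compound 2 concerns another group. Loss of the phenyl is a larger change, so a weaker number is expected for compound 3, roughly a 3.6-fold higher number from compound 1 to compound 3 (0.55 log units; beyond the scatter). Compound 3 is estimated at 2000 nM, within 600 nM to 7000 nM.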

Compound 3, half-maximal inhibitory concentration: 2130 nM
Estimate against measurement, compound 3: 1.1-fold (0.03 log units) below, within the range that was stated.
By their numbers in this assay, from the lowest: compound 1; then compounds 2 and 3 (each within the scatter of the next).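

In this assay, fluoro in place of phenyl, at the carbon ortho to a chloro group, gives a 3.8-fold higher number from compound 1 to compound 3 (0.58 log units; beyond the scatter) and so gives this position its first reading. The phenyl can be lost at the price of a modest step, and a measurable number remains with a single fluoro there. Nothing available gives a reason for this step.

On these data alone, how a methoxy group, an amine or a carboxylic acid would read at this carbon stays open. So does whether the chloro group counts for as much when fluoro replaces the phenyl.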